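The source may report more compounds than this note shows. Statements on the series, on what has been measured and on what is new or still open speak of the compounds shown alone.

Measured so far:
- compound 1, `CC(C)(C)c1ccc(Cn2nc(-c3ccccc3)cc2C(=O)N/N=C/c2ccccc2O)cc1`, gives 560 nM in a physicochemical assay on A549 cells for solubility, read by microscopy, with a stated time of 24 h; on this read-out higher numbers stand for weaker inhibition and lower numbers for stronger inhibition
- compound 2, `O=C(N/N=C/c1ccccc1O)c1cc(-c2ccc(Cl)cc2)nn1Cc1ccccc1`, gives 680 nM in this assay

Compound 2 stands at the highest of the two numbers in this assay; its nearest neighbour is compound 1, and the two values lie within the scatter of each other, so no order between them can be claimed.

Compound 3, `CC(C)(C)c1ccc(Cn2nc(-c3ccc(Cl)cc3)cc2C(=O)N/N=C/c2ccccc2O)cc1`, is the next candidate for this assay. It differs from compound 2 by tert-butyl in place of hydrogen on an aromatic carbon, which reads, one bond further out, as benzyl to 4-(tert-butyl)benzyl. Compound 1 already carries this 4-(tert-butyl)benzyl, with a plain phenyl elsewhere, and its value sits beside that of compound 2. Among the compounds with values here, no measured pair isolates this change, so the step of a 1.1-fold lower number from compound 2 to compound 3 (0.05 log units; within the scatter) is expected to stay within the scatter in either direction. Compound 3 is estimated at 600 nM, with a range of 300 nM to 1200 nM.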

Compound 3, half-maximal inhibitory concentration: 430 nM
For compound 3 the middle estimate is 1.4-fold (0.14 log units) above the measured one; measured number inside the range.
By their numbers in this assay, from the lowest: compounds 3, 1 and 2 (each within the scatter of the next).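

Compounds 1 and 2 differ in two places, so neither change could be read alone; compound 3 now isolates each of them. In this assay the change from benzyl to 4-(tert-butyl)benzyl gives a 1.6-fold lower number from compound 2 to compound 3 (0.20 log units; within the scatter), so the two groups cannot be told apart at this position on this read-out. Chloro in place of hydrogen on an aromatic carbon gives a 1.3-fold lower number from compound 1 to compound 3 (0.11 log units; within the scatter), and this change likewise cannot be resolved from the scatter. Nothing available bears on the reason for these small steps.

From the compounds shown here alone, each of these two positions has so far carried only hydrogen and one other group, so the range of values they can reach remains open. A primary amine or a carboxylic acid in place of the tert-butyl, or a methoxy group in place of the chloro, would test whether either position can give a step beyond the scatter.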